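This account rests on a few compounds, and the source may have more. Where it says the series, first, only, none or still open, it means among the compounds named here.

Compound 1 `COc1cc(/C=C/c2nc(NCc3ccccc3Cl)c3sccc3n2)cc(OC)c1OC` in a functional assay on L02 cells (Homo sapiens) for inhibition, read by Griess assay, with stated times of 1 h and 24 h (a higher number here means a weaker inhibitor, a lower number a stronger inhibitor), gives > 1000000 nM, which is a limit of the assay rather than a number.
Compound 2 `COc1cc(/C=C/c2nc(NCc3ccco3)c3sccc3n2)cc(OC)c1OC` in this assay gives 189000 nM.

Of the two entries shown, compound 2 holds the only actual number; the other entry sits at the limit of > 1000000 nM in this assay, at which 1 of the 2 values shown sits. For the measured compounds named here, the single measured step is an at least 5.2-fold lower number from compound 1 to compound 2 (0.72 log units; beyond the scatter), and it is at least modest.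

Compound 3 `COc1cc(/C=C/c2nc(OCc3ccccc3)c3sccc3n2)cc(OC)c1OC` differs from compound 2 in one place: benzyloxy in place of ((furan-2-yl)methyl)amino on an aromatic carbon. Going by the values given here, no measured step changes the atom that joins the side group to the shared core, so the only guide is an at least 5.2-fold lower number from compound 1 to compound 2 (0.72 log units; beyond the scatter), which went from a 2-chlorophenyl group to furan-2-yl; compound 3 returns to a six-membered carbon-only ring. The number for compound 3 is therefore expected to rise, by a 3.2-fold higher number from compound 2 to compound 3 (0.50 log units; beyond the scatter), with a real chance that only a limit is reported. The estimate for compound 3 is 600000 nM, within a range of 150000 nM to 3000000 nM.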

Compound 3, half-maximal inhibitory concentration: > 1000000 nM
Compound 3 gave a limit, no number; the forecaster's own chance of this, stated with the estimate: 40%; middle value at least 1.6-fold (0.22 log units) from the limit.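

For the compounds shown here, compound 3 is the first compound here in which the atom joining the side group to the shared core changes, from nitrogen to oxygen, and the hydrogen-bond donor of ((furan-2-yl)methyl)amino is lost with it. In this assay, going by these compounds alone, benzyloxy in place of ((furan-2-yl)methyl)amino on this aromatic carbon gives an at least 5.2-fold higher number from compound 2 to compound 3 (0.72 log units; beyond the scatter), so compound 2 remains the only compound with an actual number. Compound 1 and compound 3 both end at a limit, so the step between them cannot be read: the limit of > 1000000 nM in this assay, at which 2 of the 3 values shown sit.

The step changes the joining atom and the ring together, leaving open which of the two accounts for it; a (furan-2-yl)methoxy group or an unsubstituted benzylamino group would separate them. From the compounds shown here alone, whether a longer chain between the nitrogen and the furan ring lowers the number further also remains open.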